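A few compounds are considered here, and "the series" means these few. Any claim that something is new, unique, unknown or untested is made for them only; others in the source may bear on it.

Compound 1, whose structure is `O=C(Nc1cccc(-n2cc(-c3ccncc3)c(-c3ccc(Cl)c(O)c3)n2)c1)Nc1cccc(C(F)(F)F)c1`, was tested in a functional assay on UO-31 cells (Homo sapiens) for inhibition, read by sulforhodamine B assay, with a stated time of 48 h (a higher number here means a weaker inhibitor of growth, a lower number a stronger inhibitor of growth), and gave 1860 nM. Among the measured compounds shown here, only one other compound in this set has been measured: compound 2, with structure `COc1cc(-c2nn(-c3cccc(NC(=O)Nc4cccc(C(F)(F)F)c4)c3)cc2-c2ccncc2)ccc1Cl`, which in this assay gave 702 nM. Of these two numbers, compound 1 has the higher one, so among what has been measured it is the weaker growth inhibitor. For the measured compounds named here, the single measured step, a 2.6-fold lower number from compound 1 to compound 2 (0.42 log units; beyond the scatter), shows what a small change on the shared core can do.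

The next compound to consider is compound 3, with structure `O=C(Nc1cccc(-n2cc(-c3ccncc3)c(-c3ccc(Cl)c(O)c3)n2)c1)Nc1ccc(Cl)c(C(F)(F)F)c1`. It differs from compound 1 by chloro in place of hydrogen on an aromatic carbon. Going by the values given here, this change sits on the urea-linked ring of the molecule, a different part of the core from the one altered between compound 1 and compound 2, so no measured step speaks directly to it. Among the compounds with values here, the one step that exists is of modest size, and a change of similar scale, in either direction, seems the most reasonable expectation here. Compound 3 is expected to give 1100 nM, with a likely range from 400 nM to 3000 nM, a step of a 1.7-fold lower number from compound 1 to compound 3 (0.23 log units; within the scatter).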

Compound 3, concentration for 50% growth inhibition: 777 nM
Compound 3: middle estimate off by 1.4-fold (0.15 log units), on the high side; low and high end bracket the measured number.
By their numbers in this assay, from the lowest: compounds 2 and 3 (each within the scatter of the next); then compound 1.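

In this assay, the 3-(trifluoromethyl)phenyl end of the molecule proves sensitive to a very small addition: turning it into 4-chloro-3-(trifluoromethyl)phenyl, which adds a single chlorine atom, gives a 2.4-fold lower number from compound 1 to compound 3 (0.38 log units; beyond the scatter). The earlier compounds shown here showed a change only at an oxygen on an aromatic ring, with a 2.6-fold lower number from compound 1 to compound 2 (0.42 log units; beyond the scatter), so this is a second place on the molecule where one small change moves the number beyond the scatter, and again toward a stronger inhibitor of growth. No measurement offered here accounts for what the chloro group does at this carbon.

As far as these compounds go, it remains open whether this gain belongs to chloro itself or would also appear with another small group on the same carbon, such as fluoro, methyl or an amine. From the compounds shown here alone, it is also open whether the two changes add up, which a single compound combining the methyl on the oxygen with the new chloro would test.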